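Aryl sulfonamide series: dropping a chlorine from compound 1

The source may hold more compounds than are shown below. What is called first, only, known or untested is meant among the compounds shown, and "the series" means these compounds.

Compound 1 `Cc1c(Cl)ccc(S(=O)(=O)N(C)CCOCC(=O)N(C)Cc2ccc(C3=NCCN3)cc2)c1Cl` gives 2.1 nM in an assay on HEK293 cells for displacement of a labelled ligand from B1 bradykinin receptor (Homo sapiens), read by scintillation counting (on this read-out lower numbers stand for stronger inhibition and higher numbers for weaker inhibition), the second highest of the three numbers in hand. Compound 2 `COc1cc(C)c(S(=O)(=O)N(C)CCOCC(=O)N2CCN(C3CCN(C4CC4)CC3)CC2)c(C)c1` sits lower at 0.8 nM, beyond the scatter, and compound 3 `COc1cc(C)c(S(=O)(=O)N(C)CCOCC(=O)N2CCC(C(O)CN(C)C)CC2)c(C)c1` sits far higher at 30 nM, also beyond the scatter. No pair among these three differs in a single place, so no measured step guides the next change. Compound 4 `Cc1c(Cl)cccc1S(=O)(=O)N(C)CCOCC(=O)N(C)Cc1ccc(C2=NCCN2)cc1` differs from compound 1 by 3-chloro-2-methylphenyl in place of 2,4-dichloro-3-methylphenyl on a sulfonyl sulfur. With one chlorine removed from the aryl group on the sulfonyl, a small loss is expected, of the order a 2.4-fold higher number from compound 1 to compound 4 (0.38 log units; beyond the scatter), possibly still inside the scatter. Compound 4 is thus estimated at 5 nM, within the range 1.5 nM to 16 nM.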

Compound 4, inhibition constant: 6.8 nM
For compound 4 the middle estimate is 1.4-fold (0.13 log units) below the measured one; measured number inside the range.
By their numbers in this assay, from the lowest: compound 2; then compound 1; then compound 4; then compound 3.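

In this assay, going by these compounds alone, 3-chloro-2-methylphenyl in place of 2,4-dichloro-3-methylphenyl on a sulfonyl sulfur gives a 3.2-fold higher number from compound 1 to compound 4 (0.51 log units; beyond the scatter) as the first single-place step. The read-out therefore responds to the aryl group at this place, though removing this one chlorine costs only a modest step. No measurement in hand bears on the origin of this step. Going by these compounds, whether fluorine, methoxy or trifluoromethyl at the vacated place would recover the number remains open. Also open, on these data alone, is whether the step would hold with the amide part of compound 2.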